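Vinyl in place of prop-1-en-1-yl on compound 1

A few compounds are considered here, and "the series" means these few. Any claim that something is new, unique, unknown or untested is made for them only; others in the source may bear on it.

In a functional assay on JeKo-1 cells (Homo sapiens) for inhibition, read by luminescence and CellTiter-Glo, with a stated time of 72 h (on this read-out lower numbers stand for stronger inhibition and higher numbers for weaker inhibition), compound 1 (`C/C=C/C(=O)N1CCCC(n2nc(-c3ccc(Oc4ccccc4)cc3)cc2C(=O)OCC)C1`) reads 26500 nM and stands within the scatter of compound 2 (`C/C=C/C(=O)Nc1cccc(Cn2nc(-c3ccc(Oc4ccccc4)cc3)cc2C(=O)OCC)c1`) at 16700 nM while compound 3 (`C=CC(=O)Nc1cccc(Cn2nc(-c3ccc(Oc4ccccc4)cc3)cc2C(=O)OCC)c1`) gives 7600 nM and lies lower than compound 1, beyond the scatter. Compound 4 (`C=CC(=O)N1CCCC(n2nc(-c3ccc(Oc4ccccc4)cc3)cc2C(=O)OCC)C1`) carries vinyl in place of prop-1-en-1-yl on a carbonyl carbon whose other neighbours are an amide-type nitrogen in a ring (vinyl in place of prop-1-en-1-yl on a carbonyl carbon). Within the data shown here, one measured step bears on this change: a 2.2-fold lower number from compound 2 to compound 3 (0.34 log units; beyond the scatter) in this assay and it is modest, with no second pair to check it. The expected step, of like size and direction, is a 2.2-fold lower number from compound 1 to compound 4 (0.34 log units; beyond the scatter) in the same read-out. Compound 4 is estimated at 12000 nM (expected range 6000 nM to 24000 nM).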

Compound 4, half-maximal inhibitory concentration: 21200 nM
Compound 4: the middle estimate sits 1.8-fold (0.25 log units) below what was measured, within the range that was stated.
By their numbers in this assay, from the lowest: compound 3; then compounds 2, 4 and 1 (each within the scatter of the next).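

On the piperidine-free reading of this position, the carbonyl carbon on the amide-type nitrogen in a ring, vinyl in place of prop-1-en-1-yl gives a 1.3-fold lower number from compound 1 to compound 4 (0.10 log units; within the scatter) in this assay, so the change does not separate these two compounds. A single step beyond the scatter on the other core therefore does not carry over as a firm gain here, yet the two cores are not shown to respond differently: the same change on two cores in this assay, a 2.2-fold lower number (0.34 log units; beyond the scatter) from compound 2 to compound 3 and a 1.3-fold lower number (0.10 log units; within the scatter) from compound 1 to compound 4, 1.8-fold (0.24 log units) apart, within the scatter of two such steps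

Open, as far as these compounds go, is whether a longer chain or an amine-bearing chain on this carbonyl carbon would move the number in this assay beyond the scatter.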